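Aryl group change on the shared core: notes on compound 3

The source may report more compounds than this note shows. Statements on the series, on what has been measured and on what is new or still open speak of the compounds shown alone.

Measured in a functional assay on HCT-116 cells (Homo sapiens) for antiproliferative activity, with a stated time of 72 h; a higher number here means a weaker inhibitor, a lower number a stronger inhibitor:
- compound 1 `Nc1ncnn2c([C@@H]3O[C@H](CO)[C@@H](O)[C@H]3O)cc(-c3ccc(F)cc3)c12`: 42500 nM
- compound 2 `COc1ccc(-c2cc([C@@H]3O[C@H](CO)[C@@H](O)[C@H]3O)n3ncnc(N)c23)cc1`: 47100 nM

Only these two numbers exist so far, and compound 2 stands level with compound 1 within the scatter. Both sit in a weak range of this assay. The next compound, compound 3 `Cc1ccccc1-c1cc([C@@H]2O[C@H](CO)[C@@H](O)[C@H]2O)n2ncnc(N)c12`, keeps the shared core and carries 2-methylphenyl in place of 4-methoxyphenyl on an aromatic carbon.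

Going by the values given here, one measured step bears on this change. The step of a 1.1-fold higher number from compound 1 to compound 2 (0.04 log units; within the scatter) comes with methoxy in place of fluoro on an aromatic carbon, and it lies within the scatter. Among the compounds with values here, it is only a partial guide, since no measured compound carries the 2-methylphenyl group. A small step is therefore expected, with no move beyond the scatter in either direction, though the uncertainty is wide. The expected step is a 1.2-fold lower number from compound 2 to compound 3 (0.07 log units; within the scatter). Compound 3 is estimated at 40000 nM, with an expected range of 15000 nM to 90000 nM.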

Compound 3, half-maximal inhibitory concentration: > 100000 nM
Compound 3 gave a limit, no number; the forecaster's own chance of this, stated with the estimate: 20%; middle value at least 2.5-fold (0.39 log units) away from the limit.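

In this assay compound 3 stands at a limit of the assay, not at a number: the limit of > 100000 nM in this assay, at which 1 of the 3 values shown sits.

The earlier pair showed only that 4-fluorophenyl and 4-methoxyphenyl on this aromatic carbon read level, with a 1.1-fold higher number from compound 1 to compound 2 (0.04 log units; within the scatter), so the position could have looked indifferent to the aryl group. Going by these compounds alone, with 2-methylphenyl the read-out moves beyond the scatter for the first time in this set, in the weaker direction, with an at least 2.1-fold higher number from compound 2 to compound 3 (0.32 log units; beyond the scatter) and an at least 2.3-fold higher number from compound 1 to compound 3 (0.37 log units; beyond the scatter). As far as these compounds go, this position on the shared core therefore does respond to the aryl group, although both steps are bounds set by the limit, so their true size remains unknown.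

The compounds shown cannot separate the place of the substituent on the phenyl ring from its identity, since 4-methylphenyl and 2-methoxyphenyl are not among them. From the compounds shown here alone, it also remains open whether any group here, such as unsubstituted phenyl or a phenyl carrying an amine or a carboxylic acid, would bring the number down from the weak range that compound 1 and compound 2 occupy.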